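This account rests on a few compounds, and the source may have more. Where it says the series, first, only, none or still open, it means among the compounds named here.

In a functional assay on L1210 cells (Mus musculus) for inhibition, read by MTT assay (on this read-out lower numbers stand for stronger inhibition and higher numbers for weaker inhibition), three compounds have been measured so far:
Compound 1 `CCOC(=O)c1ccc(NC(=O)N2CC2C#N)cc1` gives 9700 nM.
Compound 2 `N#CC1CN1C(=O)Nc1ccc(Cl)c(Cl)c1` gives 2600 nM.
Compound 3 `N#CC1CN1C(=O)Nc1cccnc1` gives 11000 nM.

Among these, compound 1 holds the second highest number. Its value and that of compound 3 lie within the scatter of each other, while compound 2 sits clearly below it, beyond the scatter. Compound 4 `N#CC1CN1C(=O)Nc1ccc([N+](=O)[O-])cc1` has not yet been measured in this assay. It differs from compound 1 at a single place: nitro in place of ethoxycarbonyl on an aromatic carbon. Among the measured compounds shown here, no pair of measured compounds differs at only one place, so the data give no direct guide to the size of such a step. The step is expected to be small, most likely within the scatter and without a firm direction, as a 1.4-fold lower number from compound 1 to compound 4 (0.14 log units; within the scatter). Compound 4 is therefore estimated at 7000 nM, with a range from 2500 nM to 20000 nM.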

Compound 4, half-maximal inhibitory concentration: 2600 nM
Beside the measured number, compound 4's estimate is 2.7-fold (0.43 log units) above it; low and high end bracket the measured number.
By their numbers in this assay, from the lowest: compounds 2 and 4 (each within the scatter of the next); then compounds 1 and 3 (each within the scatter of the next).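

In this assay the change from ethoxycarbonyl to nitro on this aromatic carbon brings a 3.7-fold lower number from compound 1 to compound 4 (0.57 log units; beyond the scatter) and gives the series its first single-place step, showing that the number responds to the group held here. The entering group has 3 heavy atoms against 5, while the count of hydrogen-bond acceptors stays the same. Nothing available accounts for the step. As far as these compounds go, how an amine or a carboxylic acid on this carbon would read remains open. A single step also cannot separate what nitro adds from what losing ethoxycarbonyl removes.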